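Amine aryl swap: indolyl to fluorophenyl in the enaminone series

The compounds below may be only part of what the source reports. "The series", "measured", "known", "first", "only" and "open" are said of these compounds alone.

Compound 1 `COc1ccc(-c2nc(C(=O)/C=C\Nc3ccc4[nH]ccc4c3)c3ccccn23)cc1`: in a functional assay on A549 cells (Homo sapiens) for cytotoxicity, read by MTT assay, with a stated time of 48 h (on this read-out lower numbers stand for stronger inhibition and higher numbers for weaker inhibition), compound 1 gives 4800 nM
Compound 2 `O=C(/C=C\Nc1ccc2[nH]ccc2c1)c1nc(-c2ccc(C(F)(F)F)cc2)n2ccccc12`: compound 2 gives 5190 nM
Compound 3 `Cc1cc2cc(N/C=C\C(=O)c3nc(-c4ccc(F)cc4)n4ccccc34)ccc2[nH]1`: compound 3 reaches only the assay limit > 30000 nM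

Compound 1 stands at the lowest of the two numbers, with compound 2 nearest a 1.1-fold higher number from compound 1 to compound 2 (0.03 log units; within the scatter), a step within the scatter. Compound 3 sits at the limit (the limit of > 30000 nM in this assay, at which 1 of the 3 values shown sits). Compound 4 `COc1ccc(-c2nc(C(=O)/C=C\Nc3ccc(F)cc3)c3ccccn23)cc1` differs from compound 1 by 4-fluorophenyl in place of 1H-indol-5-yl on an amine nitrogen. Within the data shown here, no measured step touches the amine side of the shared core: the single measured step alters the aryl on the other side and stays within the scatter, so it gives no guide, and compound 3 keeps the indolyl amine, so its limit bears on a different change. The expectation rests on the change itself; compound 4 is estimated at 9000 nM (range 3000 nM to 30000 nM), an expected step of a 1.9-fold higher number from compound 1 to compound 4 (0.27 log units; within the scatter).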

Compound 4, half-maximal inhibitory concentration: > 30000 nM
Compound 4 gave a limit, no number; the forecaster's own chance of this, stated with the estimate: 25%; middle value at least 3.3-fold (0.52 log units) away from the limit.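

Among these compounds, the amine side of the shared core, which no earlier step touched, is not neutral in this assay: 4-fluorophenyl in place of 1H-indol-5-yl on the amine nitrogen gives an at least 6.2-fold higher number from compound 1 to compound 4 (0.79 log units; beyond the scatter). The reading for compound 4 is an assay limit, not a number, so this step has a floor but no measured size: the limit of > 30000 nM in this assay, at which 2 of the 4 values shown sit.

The compounds shown do not separate the departure of the five-membered ring and its hydrogen-bond donor from the arrival of fluorine. A plain phenyl on the same amine nitrogen would bear on that question.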